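The compounds below may be only part of what the source reports. "The series", "measured", "known", "first", "only" and "open" are said of these compounds alone.

Measured in a functional assay on PC-3 cells (Homo sapiens) for cytotoxicity, read by MTT assay, with a stated time of 48 h; a higher number here means a weaker inhibitor, a lower number a stronger inhibitor:
- compound 1 `COc1ccc(/C=C/C(=O)/C=C/c2cc3ccccc3nc2Oc2ccc(Br)cc2)cc1`: > 10000 nM (a limit)
- compound 2 `COc1ccc(/C=C/C(=O)/C=C/c2cc3ccccc3nc2Oc2ccc(Br)cc2)cc1OC`: > 10000 nM (a limit)
- compound 3 `COc1cc(OC)c(/C=C/C(=O)/C=C/c2cc3ccccc3nc2Oc2ccc(Br)cc2)c(OC)c1`: > 10000 nM (a limit)

Compound 3 has no number, only the limit > 10000 nM. For the measured compounds named here, the other two compounds share this position, so the series so far is described by the limit of > 10000 nM in this assay, at which 3 of the 3 values shown sit.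

The next compound is compound 4 `COc1cc(OC)c(/C=C/C(=O)/C=C/c2cc3ccccc3nc2Oc2cccc(Cl)c2)c(OC)c1`, not yet measured. The change is 3-chlorophenyl in place of 4-bromophenyl on an oxygen on an aromatic ring.

Going by the values given here, none of the measured steps makes this change. All three alter the methoxy-substituted phenyl group instead, and none gives a size that can be carried over. They are a step that the two limits leave unreadable from compound 1 to compound 2, a step that the two limits leave unreadable from compound 1 to compound 3 and a step that the two limits leave unreadable from compound 2 to compound 3.

Among the compounds with values here, no measured step therefore supports a direction or size for the change to 3-chlorophenyl. The expectation rests on compound 3 at > 10000 nM, which is a limit. The expected step is a step that the limit leaves unreadable from compound 3 to compound 4, an estimate with no firm direction, and a result at the same limit is the most likely outcome. For compound 4 the estimated value is 13000 nM, with an expected range of 4000 nM to 30000 nM.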

Compound 4, half-maximal inhibitory concentration: > 10000 nM
Compound 4: only a limit was reported; the forecaster's own chance of this, stated with the estimate: 75%; the middle value is on the limit's open side.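

In this assay compound 4 gives > 10000 nM and this is a limit. Compound 3 also has only a limit, so no step can be read between compound 3 and compound 4. The compounds shown leave open whether 3-chlorophenyl and 4-bromophenyl differ at all in this assay, and how strongly any of the four compounds acts there.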